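A few compounds are considered here, and "the series" means these few. Any claim that something is new, unique, unknown or untested is made for them only; others in the source may bear on it.

Working notes on the bis-amide series. In a functional assay on HEK293 cells for antagonist activity at metabotropic glutamate receptor 5 (Homo sapiens), read by FLIPR and calcium flux (on this read-out lower numbers stand for stronger inhibition and higher numbers for weaker inhibition), compound 1 `CN(C)c1cccc(C(=O)N[C@H]2CCC[C@H](NC(=O)c3cccc(Cl)c3)C2)c1` reports only > 10000 nM, which is a limit of the assay and not a number. Compound 2 `O=C(NC1CCCC(NC(=O)c2ccccn2)C1)c1cccc(Cl)c1` gives 314 nM in this assay, and compound 3 `O=C(N[C@@H]1CCC[C@@H](NC(=O)c2ccccn2)C1)c1cccc(Cl)c1` gives 62 nM, the lowest of the two numbers shown. The step of a 5.1-fold lower number from compound 2 to compound 3 (0.70 log units; beyond the scatter) rests on (the fact that one of compounds 2 and 3 is drawn with a defined configuration and the other without, at the place where they differ). Compound 4 `O=C(N[C@H]1CCC[C@H](NC(=O)c2ccccn2)C1)c1cccc(Cl)c1` differs from compound 3 only in configuration: the two compounds have the same atoms and bonds and differ only in configuration as drawn: 2 of 2 stereo elements differ (all stereocentres are inverted: mirror images); a stereocentre at a saturated ring carbon is drawn R in compound 3 and S in compound 4; a stereocentre at a saturated ring carbon is drawn R in compound 3 and S in compound 4. Given a 5.1-fold lower number from compound 2 to compound 3 (0.70 log units; beyond the scatter), the inverted pair in compound 4 is expected to carry less of the activity, so an upward step beyond the scatter is expected, a 48-fold higher number from compound 3 to compound 4 (1.68 log units; beyond the scatter). For compound 4 the estimate in this assay is 3000 nM, with a range from 500 nM to 20000 nM; a limit read-out is possible.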

Compound 4, half-maximal inhibitory concentration: > 10000 nM
Compound 4 was reported as a limit; the forecaster's own chance of this, stated with the estimate: 40%; at least 3.3-fold (0.52 log units) between middle value and limit.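

In this assay inverting both ring stereocentres gives an at least 160-fold higher number from compound 3 to compound 4 (2.20 log units; beyond the scatter) and shows that, with pyridin-2-yl on the carbonyl, the activity depends on the configuration drawn in compound 3: the fact that compounds 3 and 4 differ only in the configuration as drawn. The form without drawn configuration also stands clear of the inverted form, with an at least 31-fold higher number from compound 2 to compound 4 (1.50 log units; beyond the scatter) as the step: the fact that one of compounds 2 and 4 is drawn with a defined configuration and the other without, at the place where they differ. Compound 4 gives > 10000 nM, which is a limit of the assay and not a number.

The step from compound 1 to compound 4 cannot be read, since both values are limits. Still open, as far as these compounds go, is whether the same configuration is favoured when a morpholine or a carboxylic acid replaces pyridin-2-yl.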